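A few compounds are considered here, and "the series" means these few. Any claim that something is new, unique, unknown or untested is made for them only; others in the source may bear on it.

Of the compounds shown here, three have been tested in a functional assay on HCT-116 cells (Homo sapiens) for inhibition, read by colorimetric assay, with a stated time of 3 days; a higher number here means a weaker inhibitor, a lower number a stronger inhibitor. Compound 1 `CC(=O)C(=O)NCCCCC(=O)Nc1ccccc1` carries an acetyl group on a carbonyl carbon whose other neighbour is an amide-type nitrogen. In this assay compound 1 reaches only the limit > 100000 nM, not a number. Compound 2 `O=C(CCCCNC(=O)c1cc(=O)c(O)co1)Nc1ccccc1` differs from it by one change, (a group of 3 heavy atoms (2 carbon, 1 oxygen; no ring) in place of a group of 8 heavy atoms (5 carbon, 3 oxygen; one six-membered aromatic ring with 1 hetero atom), on a carbonyl carbon). In this assay compound 2 likewise gives only the limit > 100000 nM. Compound 3 `O=C(CCCCCNC(=O)c1cc(=O)c(O)co1)Nc1ccccc1` has a core whose difference from that of compound 2 is not broken down here. In this assay compound 3 also sits at the limit > 100000 nM. The step that the two limits leave unreadable from compound 2 to compound 1 cannot be read because of the limit of > 100000 nM in this assay, at which 3 of the 3 values shown sit. Compound 4 `CC(=O)C(=O)NCCCCCC(=O)Nc1ccccc1` carries the same change made from compound 3, (a group of 3 heavy atoms (2 carbon, 1 oxygen; no ring) in place of a group of 8 heavy atoms (5 carbon, 3 oxygen; one six-membered aromatic ring with 1 hetero atom), on a carbonyl carbon). The step that the limit leaves unreadable from compound 3 to compound 4 is estimated to stay unreadable, since the same change gave a step that the two limits leave unreadable from compound 2 to compound 1. Compound 4 is therefore expected at 150000 nM, most likely again only a limit.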

Compound 4, half-maximal inhibitory concentration: > 100000 nM
Compound 4 was reported as a limit (the forecaster's own chance of this, stated with the estimate: 90%); the middle value does not contradict the limit.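

The step from compound 3 to compound 4 cannot be read, because both compounds give only a limit, not a number: the limit of > 100000 nM in this assay, at which 4 of the 4 values shown sit. Going by these compounds, whether any related structure gives a measurable value in this assay stays open.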